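The source may report more compounds than this note shows. Statements on the series, on what has been measured and on what is new or still open speak of the compounds shown alone.

Compound 1 `CNc1nccc(N2CC[C@H](NC(=O)Nc3ccc(Cl)c(C(F)(F)F)c3)C2)n1`: 2900 nM
Compound 2 `CNc1nccc(N2CC[C@H](NC(=O)Nc3ccc(C)c(Cl)c3)C2)n1`: 4900 nM
Compound 3 `CCN1CCN(Cc2ccc(NC(=O)N[C@H]3CCN(c4ccnc(NC)n4)C3)cc2C(F)(F)F)CC1`: 4300 nM

In a functional assay on HCT-116 cells (Homo sapiens) for inhibition, with a stated time of 72 h, in the presence of a further agent that is not named here (on this read-out lower numbers stand for an effect already at smaller amounts and higher numbers for an effect only at larger amounts of compound), compound 3 gives 4300 nM. This value lies within the usual scatter of both other measurements, so the three compounds cannot be ranked.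

Compound 4 `CNc1nccc(N2CC[C@H](NC(=O)Nc3ccc(CN4CCN(C)CC4)c(C(F)(F)F)c3)C2)n1` differs from compound 3 by one small change: hydrogen in place of methyl on a saturated chain carbon bound to an amine nitrogen in a ring. In other words, ethyl becomes methyl, turning the (4-ethylpiperazin-1-yl)methyl group into (4-methylpiperazin-1-yl)methyl.

Going by the values given here, no measured pair shows this exact change. The closest evidence is a 1.5-fold higher number from compound 1 to compound 3 (0.17 log units; within the scatter). That step introduced the entire (4-ethylpiperazin-1-yl)methyl group and still stayed within the scatter. The change now in question involves only 1 carbon, so no step beyond the scatter is expected in this assay, and no direction can be favoured.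

The expected result is a 1.1-fold lower number from compound 3 to compound 4 (0.03 log units; within the scatter).

For compound 4 the estimated value is 4000 nM, with an expected range from 2000 nM to 8000 nM.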

Compound 4, half-maximal effective concentration: > 10000 nM
Compound 4 gave a limit, no number; the forecaster's own chance of this, stated with the estimate: 3%; middle value at least 2.5-fold (0.39 log units) from the limit.
By their numbers in this assay, from the lowest: compounds 1, 3 and 2 (each within the scatter of the next). At a limit, above all of these: compound 4.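

In this assay, replacing methyl with hydrogen on a saturated chain carbon bound to an amine nitrogen in a ring, which turns ethyl into methyl, gives an at least 2.3-fold higher number from compound 3 to compound 4 (0.36 log units; beyond the scatter). So one carbon at this place can count, even though swapping chloro for the whole ethyl-bearing group gave only a 1.5-fold higher number from compound 1 to compound 3 (0.17 log units; within the scatter), while the methyl-bearing group gives an at least 3.4-fold higher number from compound 1 to compound 4 (0.53 log units; beyond the scatter). Compound 4 is a limit and not a number, so both of its steps give only a smallest size: the limit of > 10000 nM in this assay, at which 1 of the 4 values shown sits.

How far compound 4 really lies from compound 3, and why, stays open. Also open, from the compounds shown here alone, is whether a propyl group, a 2-hydroxyethyl group or a bare hydrogen in place of ethyl would behave like compound 3 or like compound 4.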